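Working notes: the step from compound 1 to compound 3

The compounds below may be only part of what the source reports. "The series", "measured", "known", "first", "only" and "open" are said of these compounds alone.

Going by the values given here, in an ADME assay on L6 cells (Rattus norvegicus) for cytotoxicity, read by resazurin assay (a lower number here means a stronger inhibitor, a higher number a weaker inhibitor), compound 1 (`N=C(N)c1ccc2[nH]c(-c3ccc4nc(-c5ccc(F)c(F)c5)[nH]c4c3)nc2c1`) gives 29.8 ug/mL and holds the lower of the two numbers so far, with compound 2 (`N=C(N)c1ccc2[nH]c(-c3ccc4nc(-c5cc(C(F)(F)F)cc(C(F)(F)F)c5)[nH]c4c3)nc2c1`) at 76.8 ug/mL and the gap beyond the scatter. Compound 3 (`COc1cc(OC)cc(-c2nc3ccc(-c4nc5cc(C(=N)N)ccc5[nH]4)cc3[nH]2)c1`) carries 3,5-dimethoxyphenyl in place of 3,4-difluorophenyl on an aromatic carbon. Among the compounds with values here, no measured step covers this change. No shift beyond the scatter is expected in this assay, and a slight rise is the likelier direction. The estimated change (a 1.3-fold higher number from compound 1 to compound 3 (0.11 log units; within the scatter)) is expected to stay small. Compound 3 is expected at 38 ug/mL (range 14 ug/mL to 90 ug/mL).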

Compound 3, half-maximal inhibitory concentration: 25.5 ug/mL
Compound 3: middle estimate off by 1.5-fold (0.17 log units), on the high side; the measured number falls inside the stated range.
By their numbers in this assay, from the lowest: compounds 3 and 1 (each within the scatter of the next); then compound 2.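

In this assay, going by these compounds alone, the step of a 1.2-fold lower number from compound 1 to compound 3 (0.07 log units; within the scatter) is the first measured change at this position, on an aromatic carbon of the five-membered ring between two ring nitrogen atoms. It shows that replacing 3,4-difluorophenyl with 3,5-dimethoxyphenyl, which swaps fluorine for oxygen and brings hydrogen-bond acceptors, leaves the read-out within the scatter. No measurement shown here explains this result.

Still open, going by these compounds, is whether a phenyl group carrying an amine or a carboxylic acid at this place would also stay within the scatter of compound 1.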